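This account rests on a few compounds, and the source may have more. Where it says the series, first, only, none or still open, it means among the compounds named here.

Compound 1 `Clc1ccc(-c2cc(-c3cccs3)nc(-c3ccccc3Cl)c2)o1`: 18500 nM
Compound 2 `Clc1ccc(-c2cc(-c3ccoc3)cc(-c3cccs3)n2)cc1`: 5530 nM
Compound 3 `Cc1cccc(-c2cc(-c3ccc(Cl)o3)cc(-c3ccsc3)n2)c1`: 20300 nM

In a functional assay on HeLa cells (Homo sapiens) for cytotoxicity, in the presence of a further agent that is not named here (on this read-out lower numbers stand for stronger inhibition and higher numbers for weaker inhibition), compound 3 and compound 1 give numbers within the usual scatter of each other, while compound 2 gives a number beyond the scatter below both, so compound 3 stands among the two higher numbers. Compound 4 `Cc1ccc(-c2cc(-c3ccc(Cl)o3)cc(-c3ccsc3)n2)cc1` differs from compound 3 in one place: 4-methylphenyl in place of 3-methylphenyl on an aromatic carbon. For the measured compounds named here, no two measured compounds differ in a single place, so no measured step guides this change. Since the two compounds hold the same atoms joined differently, a step no larger than the usual scatter is expected, in either direction. Compound 4 is therefore estimated at 20000 nM in this assay, between 8000 nM and 50000 nM, which is expected to mean a 1.0-fold lower number from compound 3 to compound 4 (0.01 log units; within the scatter).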

Compound 4, half-maximal inhibitory concentration: 16200 nM
Compound 4: the middle estimate sits 1.2-fold (0.09 log units) above what was measured; the measured number falls inside the stated range.
By their numbers in this assay, from the lowest: compound 2; then compounds 4, 1 and 3 (each within the scatter of the next).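

In this assay, for the compounds shown here, moving the methyl group on the phenyl ring next to the ring nitrogen, from 3-methylphenyl to 4-methylphenyl, gives a 1.3-fold lower number from compound 3 to compound 4 (0.10 log units; within the scatter) and so offers the first comparison here between compounds that differ in one place. The two placements of the methyl group cannot be told apart at this position. Nothing measured here bears on the reason for this result. The compounds shown leave open whether a different group in place of the methyl, such as an amine or a carboxylic acid, would give a number beyond the scatter from compound 3 or compound 4.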